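The compounds below may be only part of what the source reports. "The series", "measured", "known", "first", "only" and "open" are said of these compounds alone.

Within the data shown here, in an ADME assay on MIA PaCa-2 cells (Homo sapiens) for cytotoxicity, read by MTT assay, with a stated time of 72 h (on this read-out higher numbers stand for weaker inhibition and lower numbers for stronger inhibition), compound 1 `CC(=O)OC1C/C(=N/O)C(c2ccccc2)=C1c1ccccc1` gives 4.5 ug/mL, the only exact number available. Compound 2 `COc1ccc(C2=C(c3cc(OC)c(OC)c(OC)c3)CC(O[SiH2]C(C)(C)C)C2=O)cc1[N+](=O)[O-]` reads > 100 ug/mL, which is a limit of the assay and not a number. Among the measured compounds shown here, compound 1 therefore stands alone as a measured reference point, and no measured pair differing in one place is available to show how a single change plays out in this assay.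

Compound 3 `O/N=C1/CC(O)C(c2ccccc2)=C1c1ccccc1` departs from compound 1 in one place, given by hydrogen in place of acetyl on an oxygen on a saturated carbon. In words, this is hydrogen in place of acetyl on an oxygen on a saturated carbon, or acetoxy to hydroxy, while the rest of the core of compound 1 stays the same. With only compound 1 at 4.5 ug/mL as an anchor, a moderate weakening is expected, meaning a somewhat higher number in this assay, though a result within the usual scatter would not be surprising. The estimated 2.0-fold higher number from compound 1 to compound 3 (0.30 log units; within the scatter) reflects that cautious expectation. For compound 3 the expected value is 9 ug/mL, with an estimated range of 3 ug/mL to 40 ug/mL.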

Compound 3, half-maximal inhibitory concentration: > 100 ug/mL
Compound 3: a limit, no number; the forecaster's own chance of this, stated with the estimate: 10%; middle value at least 11-fold (1.04 log units) away from the limit.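

In this assay, this position proves sensitive: going from acetoxy to hydroxy on the saturated carbon gives an at least 22-fold higher number from compound 1 to compound 3 (1.34 log units; beyond the scatter). Among these compounds, this is the first measured pair that differs in one place, and it shows that a single change at this oxygen, with the rest of the core of compound 1 kept the same, can carry the read-out well beyond the scatter, toward weaker inhibition. The step has no upper end, since the value of compound 3 is a limit and not a number: the limit of > 100 ug/mL in this assay, at which 2 of the 3 values shown sit.

The compounds shown leave open whether the acetyl group as such is what counts at this oxygen, or whether a methoxy group, a longer acyl group such as propanoyl, or an amine in the same place would stay close to compound 1 or fall toward compound 3. They also leave open how much of the hydroxy result holds on any core other than that of compound 1, and how far the true value of compound 3 lies from the limit.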